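Fluorine on the Benzamide Ring and Cell Toxicity

The source may report more compounds than this note shows. Statements on the series, on what has been measured and on what is new or still open speak of the compounds shown alone.

Measured compounds:
- compound 1 `CC(C)S(=O)(=O)n1c(N)nc2ccc(NC(=O)c3ccccc3)cc21`: > 500000 nM
- compound 2 `CC(C)S(=O)(=O)n1c(N)nc2ccc(NC(=O)c3ccccc3F)cc21`: 48000 nM
- compound 3 `CC(C)S(=O)(=O)n1c(N)nc2cc(NC(=O)c3ccccc3)ccc21`: > 500000 nM

All three were tested in an ADME assay on HepG2 2.2.15 cells (Homo sapiens) for cytotoxicity, read by MTT assay, with a stated time of 6 h; on this read-out higher numbers stand for lower toxicity in this test and lower numbers for higher toxicity in this test. For compound 1 the value > 500000 nM is a limit of the assay, not a number. Compound 2 carries the change (fluoro in place of hydrogen on an aromatic carbon), and the step of an at least 10-fold lower number from compound 1 to compound 2 (1.01 log units; beyond the scatter) shows a clearly higher toxicity in this test. Compound 3 has the same atoms as compound 1, joined differently; the difference between the two cores is not broken down here. For compound 3 the value > 500000 nM is again a limit of the assay. The limit of > 500000 nM in this assay, at which 2 of the 3 values shown sit, is where two of the three values sit, so the size of the step from compound 1 to compound 2 is known only as a lower bound.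

Compound 4 `CC(C)S(=O)(=O)n1c(N)nc2cc(NC(=O)c3ccc(F)cc3)ccc21` is not yet measured. It differs from compound 3 by fluoro in place of hydrogen on an aromatic carbon. Among the compounds with values here, this is the same kind of change as the one from compound 1 to compound 2, but not the same: there the fluoro sits ortho to a large group, here para to a large group, and the core is that of compound 3 rather than compound 1.

Against the step of an at least 10-fold lower number from compound 1 to compound 2 (1.01 log units; beyond the scatter), the step of an at least 3.3-fold lower number from compound 3 to compound 4 (0.52 log units; beyond the scatter) is expected for compound 4, resting on the single measured step and on the limit of > 500000 nM in this assay, at which 2 of the 3 values shown sit, that hides its true size. Compound 4 is expected to give about 150000 nM in this assay, within 40000 nM to 500000 nM.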

Compound 4, half-maximal cytotoxic concentration: 34000 nM
Estimate against measurement, compound 4: 4.4-fold (0.64 log units) above; measured number outside the range, below it.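

In this assay, fluoro in place of hydrogen on an aromatic carbon again gives a lower number on the second core, an at least 14-fold lower number from compound 3 to compound 4 (1.16 log units; beyond the scatter), so the direction seen with compound 2 carries over to compound 4, which means higher toxicity in this test on both cores. This is only two cases, and between them both the core and the place of the fluoro differ: in compound 4 it sits para to a large group, while in compound 2 it sits elsewhere on the ring, so these steps cannot separate what the core contributes from what the place of the fluoro contributes. Nor do they show that the change has the same size on both cores: the same change on two cores in this assay, an at least 10-fold lower number (1.01 log units; beyond the scatter) from compound 1 to compound 2 and an at least 14-fold lower number (1.16 log units; beyond the scatter) from compound 3 to compound 4; the limit leaves it open whether they differ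

The compounds shown leave open whether another group on the same ring, such as chloro, methoxy or an amine, would lower the number in the same way. They also leave open how fluoro would behave at the other places on the ring of either core, so neither the place nor the identity of the group can yet be tied to the toxicity seen here.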